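The compounds below may be only part of what the source reports. "The series", "measured", "known", "first", "only" and "open" are said of these compounds alone.

Working notes on the series. In a functional assay on the whole organism for inhibition, with Rattus norvegicus as the target, with a stated time of 2 h, at a dose of 100 mg/kg by the intraperitoneal route (a lower number here means less inhibition, a higher number more inhibition at the dose given (going by the name of the read-out)), compound 1 `Cc1nnc(-c2nsc3ccccc23)o1` gives 69%, compound 2 `c1ccc(-c2nnc(-c3nsc4ccccc34)o2)cc1` gives 60%, and compound 3 `COc1ccc(-c2nnc(-c3nsc4ccccc34)o2)cc1` gives 45%. Compound 2 stands second highest of the three numbers, nearest compound 1 within the scatter and furthest from compound 3 beyond it. Compound 4 `CCNc1nnc(-c2nsc3ccccc23)o1` is not yet measured; it differs from compound 2 by ethylamino in place of phenyl on an aromatic carbon. Among the compounds with values here, two measured steps bear on this carbon: a number 9 percentage points lower from compound 1 to compound 2 (within the scatter) and a number 15 percentage points lower from compound 2 to compound 3 (beyond the scatter). Neither involves an ethylamino group, and since a number 9 percentage points lower from compound 1 to compound 2 (within the scatter) stayed within the scatter with phenyl in place of methyl, no step beyond the scatter is expected in this assay, with a small drop at most. The estimate for compound 4 is 58%, range 40% to 76%. This corresponds to an expected step of a number 2 percentage points lower from compound 2 to compound 4 (within the scatter).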

Compound 4, a percentage reported as inhibition, in the whole organism at one dose (the size of the read-out at that dose, not a potency): 65%
Compound 4: the middle estimate sits 7 percentage points below what was measured; the measured number falls inside the stated range.
By their numbers in this assay, from the lowest: compound 3; then compounds 2, 4 and 1 (each within the scatter of the next).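

In this assay, this aromatic carbon accepts ethylamino, which has no ring and brings a nitrogen and a hydrogen-bond donor, in place of phenyl, with a number 5 percentage points higher from compound 2 to compound 4 (within the scatter), and in place of methyl, with a number 4 percentage points lower from compound 1 to compound 4 (within the scatter). Methyl, phenyl and ethylamino on this carbon therefore cannot be told apart in this read-out, so neither a ring nor a nitrogen on this carbon separates these compounds. No measured evidence bears on why these groups read alike. On these data alone, it remains open whether a longer chain such as butylamino, or dimethylamino, which lacks the amine hydrogen, would keep the number. As far as these compounds go, a carboxylic acid on this carbon also remains untested in these data.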